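Replacing pyridin-4-yl with 5-nitrofuran-2-yl on the carbonyl carbon

The source may report more compounds than this note shows. Statements on the series, on what has been measured and on what is new or still open speak of the compounds shown alone.

- compound 1 `COc1ccc(C2CC(c3ccccc3)=NN2C(=O)c2nc3ccccc3s2)cc1` gives 1900 nM
- compound 2 `COc1ccccc1C1=NN(C(=O)c2ccncc2)C(c2ccc([N+](=O)[O-])cc2)C1` gives 2600 nM

Both values were obtained in a functional assay on HCT-15 cells (Homo sapiens) for antiproliferative activity, read by CCK-8 assay, with a stated time of 72 h (a higher number here means a weaker inhibitor, a lower number a stronger inhibitor), and they lie within the scatter of each other. Compound 2 (2600 nM) therefore stands level with compound 1 (1900 nM), and neither can be ranked above the other. The two compounds differ in more than one place, so their values say little about any single change.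

Compound 3 (`COc1ccccc1C1=NN(C(=O)c2ccc([N+](=O)[O-])o2)C(c2ccc([N+](=O)[O-])cc2)C1`) has not yet been measured. It carries 5-nitrofuran-2-yl in place of the pyridin-4-yl of compound 2 on a carbonyl carbon (5-nitrofuran-2-yl in place of pyridin-4-yl on a carbonyl carbon). Within the data shown here, no measured pair in this small set shows a change at this place alone, so the expectation is a cautious one. A small move towards a lower number in this assay is expected, one that stays within the usual scatter (a 1.7-fold lower number from compound 2 to compound 3 (0.24 log units; within the scatter)). The estimate for compound 3 is 1500 nM (expected range 400 nM to 5000 nM).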

Compound 3, half-maximal inhibitory concentration: > 50000 nM
Compound 3: only a limit was reported; the forecaster's own chance of this, stated with the estimate: 3%; at least 33-fold (1.52 log units) between middle value and limit.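

On a carbonyl carbon whose other neighbour is an amide-type nitrogen in a ring, placing 5-nitrofuran-2-yl where pyridin-4-yl stood gives an at least 19-fold higher number from compound 2 to compound 3 (1.28 log units; beyond the scatter) in this assay, so activity at this place depends strongly on the group it carries. The value of compound 3 is a limit and not a number: the limit of > 50000 nM in this assay, at which 1 of the 3 values shown sits.
Compound 1 and compound 2 differ in more than one place and stand level within the scatter, so they gave no view of this position alone, whereas this single change shows that pyridin-4-yl cannot be exchanged for 5-nitrofuran-2-yl here without a large step towards a weaker inhibitor.

On these data alone, a single step cannot separate the part played by the nitro group of 5-nitrofuran-2-yl from that of the five-membered aromatic ring, and the full size of the step stays open while one end of it is a limit. The compounds shown also leave open how this place would respond to furan-2-yl without the nitro group or to a plain phenyl, and whether the same exchange would have a similar effect on the core of compound 1.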